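Replacing a dichlorophenyl group with a tert-butylsulfanyl group

This account rests on a few compounds, and the source may have more. Where it says the series, first, only, none or still open, it means among the compounds named here.

Of the compounds shown here, three with a shared core have been measured in a functional assay for inhibition of sodium/hydrogen exchanger (Oryctolagus cuniculus); a higher number here means a weaker inhibitor, a lower number a stronger inhibitor. Compound 1 `CCCCCc1cc(C)c(C(=O)N=C(N)N)cc1S(C)(=O)=O` gives 27 nM, compound 2 `Cc1cc(C2CCCCC2)c(S(C)(=O)=O)cc1C(=O)N=C(N)N` gives 22 nM, and compound 3 `Cc1cc(-c2ccc(Cl)cc2Cl)c(S(C)(=O)=O)cc1C(=O)N=C(N)N` gives 42 nM. Compound 3 holds the highest of the three numbers, yet neither gap reaches beyond the scatter: the nearest is a 1.6-fold higher number from compound 1 to compound 3 (0.19 log units; within the scatter), the furthest a 1.9-fold higher number from compound 2 to compound 3 (0.28 log units; within the scatter).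

Compound 4 `Cc1cc(SC(C)(C)C)c(S(C)(=O)=O)cc1C(=O)N=C(N)N` is not yet measured. The change from compound 3 is (tert-butyl)sulfanyl in place of 2,4-dichlorophenyl on an aromatic carbon. Within the data shown here, the steps that bear on this position all exchange one group for another on the same aromatic carbon: a 1.2-fold lower number from compound 1 to compound 2 (0.09 log units; within the scatter), a 1.6-fold higher number from compound 1 to compound 3 (0.19 log units; within the scatter) and a 1.9-fold higher number from compound 2 to compound 3 (0.28 log units; within the scatter), every one of them within the scatter. Among the measured compounds shown here, no measured step involves a (tert-butyl)sulfanyl group, so the expectation rests on the observation that the three groups tried so far gave numbers close to one another. The step of a 1.5-fold lower number from compound 3 to compound 4 (0.18 log units; within the scatter) is therefore expected to be small, leaning toward a slightly lower number as seen for compound 1 at 27 nM and compound 2 at 22 nM. Compound 4 is estimated at 28 nM, with a range from 12 nM to 70 nM.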

Compound 4, half-maximal inhibitory concentration: 22 nM
Beside the measured number, compound 4's estimate is 1.3-fold (0.10 log units) above it, within the range that was stated.
By their numbers in this assay, from the lowest: compounds 2, 4, 1 and 3 (each within the scatter of the next).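

In this assay the position ortho to a methylsulfonyl group now carries a group attached through sulfur, and the exchange of 2,4-dichlorophenyl for (tert-butyl)sulfanyl gives a 1.9-fold lower number from compound 3 to compound 4 (0.28 log units; within the scatter) and so does not separate the two groups. Set against the other groups, (tert-butyl)sulfanyl gives no change at the digits printed from compound 2 to compound 4 (within the scatter) for cyclohexyl and a 1.2-fold lower number from compound 1 to compound 4 (0.09 log units; within the scatter) for pentyl, so the four groups, with and without a ring, all lie within the scatter of one another and no compound shown goes against this. Nothing shown gives a reason for this closeness.

The compounds leave open whether an amine, a carboxylic acid or a hydroxyl group on this carbon would stay as close. They also leave open whether a smaller sulfur-linked group such as methylsulfanyl, or an oxygen-linked tert-butoxy group, would do the same.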